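Fluoro for hydrogen on the aniline ring: compound 3 to compound 4

This account rests on a few compounds, and the source may have more. Where it says the series, first, only, none or still open, it means among the compounds named here.

Measured compounds:
compound 1 `Cc1ccc(-n2nc(C(=O)Nc3ccc(Oc4ncnc5ccsc45)cc3)c(C)cc2=O)cc1`: 11500 nM
compound 2 `Cc1cc(=O)n(-c2ccccc2OC(F)(F)F)nc1C(=O)Nc1ccc(Oc2ncnc3sccc23)cc1`: 15500 nM
compound 3 `Cc1ccc(-n2nc(C(=O)Nc3ccc(Oc4ncnc5sccc45)cc3)c(C)cc2=O)cc1`: > 40000 nM

In a functional assay on A549 cells (Homo sapiens) for cytotoxicity, read by MTT assay, with a stated time of 72 h (on this read-out higher numbers stand for weaker inhibition and lower numbers for stronger inhibition), compound 1 gives 11500 nM and compound 2 gives 15500 nM. For compound 3 the value > 40000 nM is a limit of the assay and not a number (the limit of > 40000 nM in this assay, at which 1 of the 3 values shown sits). Compound 3 thus stands as the weakest of the three measured compounds: an at least 3.4-fold higher number from compound 1 to compound 3 (0.54 log units; beyond the scatter) and an at least 2.5-fold higher number from compound 2 to compound 3 (0.41 log units; beyond the scatter), both beyond the scatter.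

Compound 4 `Cc1ccc(-n2nc(C(=O)Nc3ccc(Oc4ncnc5sccc45)c(F)c3)c(C)cc2=O)cc1` differs from compound 3 in one place: fluoro in place of hydrogen on an aromatic carbon. Neither measured step touches this position; one exchanges the group on the ether oxygen, the other the group on the aromatic nitrogen. Among the measured compounds shown here, no measured step therefore bears on the change from compound 3 to compound 4, and no step beyond the scatter is expected: a step that the limit leaves unreadable from compound 3 to compound 4 is the expected step in this assay. Compound 4 is accordingly expected to give about 50000 nM in this assay, with a range from 20000 nM to 150000 nM, and most likely again only a limit rather than a number.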

Compound 4, half-maximal inhibitory concentration: > 40000 nM
Compound 4: no number, only a limit (the forecaster's own chance of this, stated with the estimate: 70%); the middle value does not contradict the limit.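

Compound 3 and compound 4 both give a limit of the assay and not a number, so no step can be read between them: the limit of > 40000 nM in this assay, at which 2 of the 4 values shown sit.

Left open is whether fluoro in place of hydrogen on an aromatic carbon shifts this read-out in either direction.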